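The compounds below may be only part of what the source reports. "The series", "measured", "known", "first", "only" and "open" are said of these compounds alone.

Measured so far in a functional assay on CCRF-CEM cells (Homo sapiens) for inhibition, read by sulforhodamine B assay, with a stated time of 48 h; on this read-out higher numbers stand for weaker inhibition of growth and lower numbers for stronger inhibition of growth:
compound 1 `COc1ccc(-c2cc(-c3cccn3C)c(C#N)c(=O)[nH]2)cc1OC` — 5010 nM
compound 2 `Cn1cccc1-c1cc(-c2cccs2)nc(N)c1C#N` — > 100000 nM
compound 3 `Cn1cccc1-c1cc(-c2ccccc2)[nH]c(=O)c1C#N` — > 100000 nM

Within the data shown here, compound 1 gives the only numerical value of the three, 5010 nM in this assay. For compound 2 the result is a limit of the assay, > 100000 nM, not a number. For compound 3 the result is likewise a limit, > 100000 nM. Compound 2 therefore stands at the limit of > 100000 nM in this assay, at which 2 of the 3 values shown sit; no ranking against the other two is possible from this.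

Compound 4 `Cn1cccc1-c1cc(-c2ccccc2)nc(N)c1C#N` has not been measured. It differs from compound 2 by phenyl in place of thiophen-2-yl on an aromatic carbon — phenyl in place of thiophen-2-yl on an aromatic carbon. Among the measured compounds shown here, no pair of measured compounds differs in one place, so nothing sizes this change directly. Compound 3 also carries a phenyl group and gives only a limit. No shift beyond the scatter is expected. Compound 4 is expected to stay at the limit, estimated at 100000 nM (range 30000 nM to 300000 nM). The expected step is a number no higher from compound 2 to compound 4 (the limit leaves the size open).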

Compound 4, concentration for 50% growth inhibition: 80 nM
Beside the measured number, compound 4's estimate is 1300-fold (3.10 log units) above it; measured number below the stated range.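

In this assay, the group on the aromatic carbon next to the ring nitrogen and para to the cyano group proves decisive for this pair: phenyl in place of thiophen-2-yl gives an at least 1200-fold lower number from compound 2 to compound 4 (3.09 log units; beyond the scatter). Compound 2 stands at > 100000 nM, a limit of the assay and not a number. This is the first step in the series that sizes a change at this position, and its full size stays open on one side: the limit of > 100000 nM in this assay, at which 2 of the 4 values shown sit.

As far as these compounds go, only phenyl and thiophen-2-yl are compared at this position, so it remains open whether a furan-2-yl or a fluorophenyl group there would behave like phenyl or like thiophen-2-yl. The compounds shown also leave open how a methylamino group in place of the amino group would alter the value of compound 4.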